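Anilino variation on the shared tricyclic core

The source may hold more compounds than are shown below. What is called first, only, known or untested is meant among the compounds shown, and "the series" means these compounds.

Measured so far in a functional assay on MCF7 cells (Homo sapiens) for inhibition, read by sulforhodamine B assay; on this read-out higher numbers stand for weaker inhibition and lower numbers for stronger inhibition:
compound 1 `Cc1ccc(NC2=CC(=O)c3nc4n(c3C2=O)[C@H]2OC[C@@H](O)[C@H]2OC4)cc1` — 1660 nM
compound 2 `Cc1ccc(NC2=CC(=O)c3nc4n(c3C2=O)[C@H]2OC[C@@H](O)[C@H]2OC4)cc1C` — 2080 nM
compound 3 `CCOc1ccc(NC2=CC(=O)c3c(nc4n3[C@H]3OC[C@@H](O)[C@H]3OC4)C2=O)cc1` — this value is only a limit of the assay, > 4000 nM

Compound 2 holds the highest of the two numbers; its nearest neighbour is compound 1, and a 1.3-fold higher number from compound 1 to compound 2 (0.10 log units; within the scatter).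

Compound 4 `COc1cccc(NC2=CC(=O)c3nc4n(c3C2=O)[C@H]2OC[C@@H](O)[C@H]2OC4)c1` differs from compound 2 in one place: 3-methoxyphenyl in place of 3,4-dimethylphenyl on an amine nitrogen. Among the measured compounds shown here, only one measured step touches this part of the structure, the methyl-for-hydrogen exchange a 1.3-fold higher number from compound 1 to compound 2 (0.10 log units; within the scatter), and it stayed within the scatter. For the measured compounds named here, no measured step covers an alkoxy-for-methyl exchange, so the expectation rests on the flat behaviour seen so far. For compound 4 a small step is expected, a 1.2-fold higher number from compound 2 to compound 4 (0.08 log units; within the scatter), with the estimate 2500 nM and a range from 1000 nM to 6000 nM.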

Compound 4, half-maximal inhibitory concentration: > 4000 nM
Compound 4: no number, only a limit; the forecaster's own chance of this, stated with the estimate: 25%; middle value at least 1.6-fold (0.20 log units) from the limit.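

In this assay compound 4 gives only a limit of the assay, > 4000 nM. Among the compounds shown here, this position is therefore not flat for every group: the record now reads an at least 2.4-fold higher number from compound 1 to compound 4 (0.38 log units; beyond the scatter), the first change here beyond the scatter, and an at least 1.9-fold higher number from compound 2 to compound 4 (0.28 log units; that floor lies within the scatter), whose floor alone cannot separate the pair. The 3-methoxyphenyl compound and the ethoxy-bearing compound 3 share one limit: the limit of > 4000 nM in this assay, at which 2 of the 4 values shown sit.

As far as these compounds go, how far past that limit either compound lies stays open. Also open, from the compounds shown here alone, is whether an amine or a carboxylic acid on the phenyl ring would give a number below it.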